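Swapping a chloroalkyl tail for a single bromine

This account rests on a few compounds, and the source may have more. Where it says the series, first, only, none or still open, it means among the compounds named here.

Compounds measured so far:
- Compound 1, `CCC/C=C/C(=O)N(Cc1ccc(OC)c(O)c1)c1cc(OC)c(OC)c(OC)c1`: 57 nM
- Compound 2, `COc1ccc(CN(C(=O)CCl)c2cc(OC)c(OC)c(OC)c2)cc1O`: 210 nM
- Compound 3, `COc1ccc(CN(C(=O)CCCCCl)c2cc(OC)c(OC)c(OC)c2)cc1O`: 770 nM

All three share one core, an amide nitrogen carrying a benzyl group and a trimethoxyphenyl group, and differ only in what hangs on the carbonyl carbon. In a functional assay on KYSE-450 cells (Homo sapiens) for inhibition, read by MTT assay, with a stated time of 48 h (a higher number here means a weaker inhibitor, a lower number a stronger inhibitor), compound 3 gives the highest number of the three: it lies a 14-fold higher number from compound 1 to compound 3 (1.13 log units; beyond the scatter) and a 3.7-fold higher number from compound 2 to compound 3 (0.56 log units; beyond the scatter).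

Compound 4, `COc1ccc(CN(C(=O)CBr)c2cc(OC)c(OC)c(OC)c2)cc1O`, has not been measured. It differs from compound 3 as follows: bromo in place of 3-chloropropyl on a saturated chain carbon bound to a carbonyl carbon. The chain on the carbonyl is thus cut back to a single halogen, much as in compound 2, where a chloromethyl sits on that carbonyl.

Going by the values given here, the step that bears most directly on this is the one from compound 2 to compound 3, in which lengthening the halogenated chain gave a 3.7-fold higher number from compound 2 to compound 3 (0.56 log units; beyond the scatter). Reversing that direction, with bromine instead of chlorine, should recover most of that loss, so compound 4 is expected to land near compound 2, a step of about a 5.1-fold lower number from compound 3 to compound 4 (0.71 log units; beyond the scatter). The estimate for compound 4 in this assay is 150 nM, with a plausible range from 50 nM to 450 nM.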

Compound 4, half-maximal inhibitory concentration: 120 nM
Compound 4: the middle estimate sits 1.3-fold (0.10 log units) above what was measured; measured number inside the range.
By their numbers in this assay, from the lowest: compound 1; then compounds 4 and 2 (each within the scatter of the next); then compound 3.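

In this assay, the change from the chlorine-bearing tail to bromomethyl on the carbonyl carbon gives a 6.4-fold lower number from compound 3 to compound 4 (0.81 log units; beyond the scatter), so a short halogen-bearing group now outperforms the longer tail in two compounds rather than one. Exchanging the halogen on that short group gives a 1.8-fold lower number from compound 2 to compound 4 (0.24 log units; within the scatter), so no difference between chlorine and bromine can be read here, while the pent-1-en-1-yl group remains ahead, with a 2.1-fold higher number from compound 1 to compound 4 (0.32 log units; beyond the scatter). No supporting measurement is available to explain any of these differences.

On these data alone, it remains open whether a halogen is needed at all, a question that a plain methyl on the carbonyl carbon would address. A 4-bromobutyl tail would show whether the penalty of the longer chain also holds with bromine.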